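Methyl on the amide nitrogen of compound 1: expected solubility

A few compounds are considered here, and "the series" means these few. Any claim that something is new, unique, unknown or untested is made for them only; others in the source may bear on it.

Among the measured compounds shown here, compound 1 `N#Cc1ccc(-c2cc(-c3ccc(C(N)=O)cc3)cc(-c3ccco3)n2)cc1` is one of two compounds measured here in a physicochemical assay for solubility, at pH 6; a higher number here means a more soluble compound, a lower number a less soluble compound. In this assay, for the measured compounds named here, compound 1 gives 10000 nM, and its only neighbour, compound 2 `Cn1ccnc1-c1cc(-c2ccc(C(N)=O)cc2)cc(-c2ccc(C#N)cc2)n1`, gives 8000 nM; the two numbers lie within the scatter of each other, so neither can be called the more soluble. Going by the values given here, the single measured step, a 1.3-fold lower number from compound 1 to compound 2 (0.10 log units; within the scatter), concerns the exchange of one ring for another and shows no change beyond the scatter.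

Compound 3 `CNC(=O)c1ccc(-c2cc(-c3ccc(C#N)cc3)nc(-c3ccco3)c2)cc1` is to be measured next. It differs from compound 1 by methyl in place of hydrogen on an amide-type nitrogen. Among the compounds with values here, no measured step touches the amide, so the data give no direct guide; the one step recorded, at a different place in the molecule, stayed within the scatter. The step expected is therefore a 1.3-fold lower number from compound 1 to compound 3 (0.10 log units; within the scatter), meaning no change that would stand out. Compound 3 is estimated at 8000 nM, with a range from 3000 nM to 20000 nM.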

Compound 3, solubility: 25000 nM
The estimate for compound 3 lay 3.1-fold (0.49 log units) below the measured number; measured number outside the range, above it.
By their numbers in this assay, from the lowest: compounds 2 and 1 (each within the scatter of the next); then compound 3.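

In this assay, among the compounds shown here, methyl in place of hydrogen on the amide-type nitrogen gives a 2.5-fold higher number from compound 1 to compound 3 (0.40 log units; beyond the scatter) and so shows that a change at this nitrogen, which no earlier step touched, can move the measured number beyond the scatter. The earlier step reads a 1.3-fold lower number from compound 1 to compound 2 (0.10 log units; within the scatter) and concerned an exchange of rings at another place, so the amide change is the only one shown here that stands out. Nothing available explains why the number rises with this methyl.

As far as these compounds go, it remains open whether a longer chain on the same nitrogen, such as ethyl or propyl, or a second methyl there, would raise the number further or lower it. The compounds shown also leave open whether this methyl would give a similar step on compound 2, which carries 1-methyl-1H-imidazol-2-yl in place of furan-2-yl.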